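Iodo analogue bearing the ring-nitrogen sulfonyl group: series notes

The source may report more compounds than this note shows. Statements on the series, on what has been measured and on what is new or still open speak of the compounds shown alone.

The series comprises compound 1 `COc1ccc(-c2c(Cl)c(=O)c3c(OC)cc(OC)cc3n2S(=O)(=O)c2ccc(OC)cc2)cc1`, compound 2 `COc1ccc(-c2c(Br)c(=O)c3c(OC)cc(OC)cc3n2S(=O)(=O)c2ccc(OC)cc2)cc1`, compound 3 `COc1ccc(-c2[nH]c3cc(OC)cc(OC)c3c(=O)c2I)cc1` and the not yet measured compound 4 `COc1ccc(-c2c(I)c(=O)c3c(OC)cc(OC)cc3n2S(=O)(=O)c2ccc(OC)cc2)cc1`. In a functional assay on HepG2 cells (Homo sapiens) for antiproliferative activity, with a stated time of 72 h (on this read-out higher numbers stand for an effect only at larger amounts of compound and lower numbers for an effect already at smaller amounts), compound 1 gives "not determined" (no result reported). For compound 2 this assay reports only a limit, > 20000 nM. For compound 3 this assay also reports only a limit, > 86200 nM. Among the measured compounds shown here, compound 3 therefore stands at the limit of > 86200 nM in this assay, at which 1 of the 3 values shown sits, the second reported value stands at the limit of > 20000 nM in this assay, at which 1 of the 3 values shown sits, and no single number exists in the whole series, so no measured step between compounds can be stated.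

Compound 4 differs from compound 3 by (4-methoxyphenyl)sulfonyl in place of hydrogen on an aromatic nitrogen; in words, (4-methoxyphenyl)sulfonyl in place of hydrogen on an aromatic nitrogen. Compound 2 already carries this (4-methoxyphenyl)sulfonyl group and shows only the limit > 20000 nM in this assay. The step from compound 3 to compound 4 is accordingly expected to be an at least 2.1-fold lower number from compound 3 to compound 4 (0.33 log units; beyond the scatter), that is, no change beyond the usual scatter, with both compounds remaining at the limit of the assay. Compound 4 is expected to give about 40000 nM in this assay, within a range from 10000 nM to 150000 nM, most probably reported again only as a limit rather than as a number.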

Compound 4, half-maximal effective concentration: > 17300 nM
Compound 4: no number, only a limit; the forecaster's own chance of this, stated with the estimate: 80%; the middle value lies beyond the limit too.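

In this assay compound 4 gives > 17300 nM, a limit and not a number. The steps to compound 4 from compound 3 and from compound 2 therefore cannot be read. The compounds shown leave open the size of any change for (4-methoxyphenyl)sulfonyl in place of hydrogen on an aromatic nitrogen. They also leave open the size of any change for iodo in place of bromo on an aromatic carbon.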